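Fluoro for Bromo: Expected Shift in Partition Coefficient

The compounds below may be only part of what the source reports. "The series", "measured", "known", "first", "only" and "open" are said of these compounds alone.

Compound 2 `Cc1ccc(Oc2ccc(/C=N/NC(=S)Nc3ccc(Br)cc3)cc2)cc1` gives 6.17 in a physicochemical assay for lipophilicity, in phosphate buffer, measured as octanol-water partition, with a stated time of 24 h (on this read-out higher numbers stand for higher lipophilicity and lower numbers for lower lipophilicity), the higher of the two numbers measured, and compound 1 `Cc1ccc(Oc2ccc(/C=N/NC(=S)Nc3ccccc3)cc2)cc1` gives 5.39. Among the measured compounds shown here, the only measured step, a number 0.78 log units higher from compound 1 to compound 2 (beyond the scatter), sets bromo against hydrogen. Compound 3 `Cc1ccc(Oc2ccc(/C=N/NC(=S)Nc3ccc(F)cc3)cc2)cc1` differs from compound 2 by fluoro in place of bromo on an aromatic carbon. For the measured compounds named here, no measured step sets fluoro against bromo directly, so the expectation rests on that single step and places compound 3 between compound 1 and compound 2. For compound 3 the step of a number 0.62 log units lower from compound 2 to compound 3 (beyond the scatter) is expected, a downward move smaller than the step from hydrogen to bromo. Compound 3 is estimated at 5.55, within a range of 5.2 to 5.9.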

Compound 3, partition coefficient: 5.48
Compound 3: the middle estimate sits 0.07 log units above what was measured; the measured number falls inside the stated range.
By their numbers in this assay, from the lowest: compounds 1 and 3 (each within the scatter of the next); then compound 2.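

In this assay fluoro in place of bromo gives a number 0.69 log units lower from compound 2 to compound 3 (beyond the scatter) and so shows that the rise seen with bromo on this aromatic carbon does not extend to both halogens. Fluoro in place of hydrogen gives a number 0.09 log units higher from compound 1 to compound 3 (within the scatter) and leaves the two compounds indistinguishable on this read-out. Nothing at hand explains why the two halogens part here. Going by these compounds, whether chloro, methoxy, an amine or a carboxylic acid at this place would stay near hydrogen or move as bromo does remains open. So does whether these steps hold on any other core.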